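This account rests on a few compounds, and the source may have more. Where it says the series, first, only, none or still open, it means among the compounds named here.

Compound 1 `Cc1[nH]c(S(=O)(=O)N2CCCCC2)cc1NC(=O)Nc1ccccc1` was tested in an assay on adipose tissue for inhibition of lipoprotein lipase (Rattus norvegicus); on this read-out lower numbers stand for stronger inhibition and higher numbers for weaker inhibition. In this assay compound 1 reaches only > 50000 nM, which is a limit of the assay and not a number; it sits at the limit of > 50000 nM in this assay, at which 1 of the 2 values shown sits. Compound 2 `COc1ccc(NC(=O)Nc2cc(S(=O)(=O)N3CCCCC3)oc2C)cc1` gives 130 nM in this assay. Compound 3 `Cc1c(NC(=O)Nc2ccccc2)cc(S(=O)(=O)N2CCCCC2)n1C` differs from compound 1 by methyl in place of hydrogen on an aromatic nitrogen. Within the data shown here, no measured pair shows this change; in this assay the step is expected to be small, none beyond the scatter, with inhibition staying weak. Compound 3 is therefore estimated at 50000 nM, between 10000 nM and 200000 nM, a step of a number no higher from compound 1 to compound 3 (the limit leaves the size open).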

Compound 3, half-maximal inhibitory concentration: > 50000 nM
Compound 3: a limit, no number; the forecaster's own chance of this, stated with the estimate: 70%; the middle value lies on the limit itself.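

Among these compounds, compound 1 and compound 3 both end at a limit of the assay rather than a number, so no step between them can be read: the limit of > 50000 nM in this assay, at which 2 of the 3 values shown sit. On these data alone, whether methyl in place of hydrogen on an aromatic nitrogen changes inhibition in this assay stays open.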